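A few compounds are considered here, and "the series" means these few. Any claim that something is new, unique, unknown or untested is made for them only; others in the source may bear on it.

Working notes on the aryloxyacetamide series.

Compound 1 `Cc1ccc(OCC(=O)N(CCO)Cc2cccs2)cc1` carries a 2-hydroxyethyl group on the amide-type nitrogen; in an assay on HEK293 cells for agonist activity at transient receptor potential cation channel subfamily M member 8 (Homo sapiens), read by fluorescence and calcium flux, with a stated time of 15 min (on this read-out lower numbers stand for an effect already at smaller amounts and higher numbers for an effect only at larger amounts of compound), compound 1 gives 900 nM. Compound 2 `Cc1ccc(OCC(=O)N(Cc2cccs2)c2ccn[nH]2)cc1` bears a 1H-pyrazol-5-yl group at the same position, and in this assay compound 2 gives 0.2 nM. Compound 3 `Cc1ccc(OCC(=O)N(Cc2cccs2)c2ccccc2)cc1` has phenyl there; in this assay compound 3 gives 23 nM. Among the three measured numbers compound 3 stands second highest: its nearest neighbour is compound 1, with a 39-fold lower number from compound 1 to compound 3 (1.59 log units; beyond the scatter), while the step of a 120-fold higher number from compound 2 to compound 3 (2.06 log units; beyond the scatter) separates it from compound 2. The step of a 4500-fold lower number from compound 1 to compound 2 (3.65 log units; beyond the scatter) shows the spread of the whole series.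

Compound 4 `Cc1ccc(OCC(=O)N(O)Cc2cccs2)cc1` is the next entry, differing from compound 3 as follows: hydroxy in place of phenyl on an amide-type nitrogen. For the measured compounds named here, the steps that bear on this are those from compound 1 to compound 3 and from compound 2 to compound 3, both changes at the same amide-type nitrogen and both large. Going by the values given here, a hydroxy group, as a single heavy atom with one donor and one acceptor, resembles neither substituent closely, and no measured pair shows this exact change. On the pattern that the small polar 2-hydroxyethyl group in compound 1 gives 900 nM, a higher number than compound 3 is expected, in the direction of compound 1, that is an expected step of a 26-fold higher number from compound 3 to compound 4 (1.42 log units; beyond the scatter). Compound 4 is therefore estimated at 600 nM, with a range from 100 nM to 4000 nM.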

Compound 4, half-maximal effective concentration: 8000 nM
Compound 4: the middle estimate sits 13-fold (1.12 log units) below what was measured, and the stated range ends below it.
By their numbers in this assay, from the lowest: compound 2; then compound 3; then compound 1; then compound 4.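

In this assay the hydroxy group gives the highest number of the four compounds, with a 350-fold higher number from compound 3 to compound 4 (2.54 log units; beyond the scatter) and a 40000-fold higher number from compound 2 to compound 4 (4.60 log units; beyond the scatter) marking the full reach of this amide-type nitrogen so far. Compound 1 no longer marks the high end of the series, since an 8.9-fold higher number from compound 1 to compound 4 (0.95 log units; beyond the scatter) is a modest step that still lies beyond the scatter; across these four compounds, phenyl and 1H-pyrazol-5-yl give lower numbers than 2-hydroxyethyl and hydroxy, and none goes against this. Nothing available explains these differences.

Open, from the compounds shown here alone, is how a plain methyl or a saturated cyclohexyl group would read at this nitrogen, which would separate the presence of a ring from its aromatic character. Also open, going by these compounds, is where a pyridyl or an imidazolyl group would fall relative to phenyl and 1H-pyrazol-5-yl.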